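Lengthening the chain beyond compound 2

The compounds below may be only part of what the source reports. "The series", "measured", "known", "first", "only" and "open" are said of these compounds alone.

Of the compounds shown here, two sharing one core have been measured so far in a functional assay on MDA cells (Homo sapiens) for inhibition, read by MTT assay, with a stated time of 48 h; a higher number here means a weaker inhibitor, a lower number a stronger inhibitor. Compound 1 `O=C(CCCOc1no[n+]([O-])c1S(=O)(=O)c1ccccc1)NO` gives 6200 nM, and compound 2 `O=C(CCCCOc1no[n+]([O-])c1S(=O)(=O)c1ccccc1)NO` gives 2530 nM, the lower of the two numbers and so the stronger inhibitor of this pair. The next structure, compound 3 `O=C(CCCCCCOc1no[n+]([O-])c1S(=O)(=O)c1ccccc1)NO`, keeps the core and alters only the chain that ends in the hydroxycarbamoyl group: 2-(hydroxycarbamoyl)ethyl in place of hydroxycarbamoyl on a saturated chain carbon, four bonds along the chain from an oxygen on an aromatic ring. In words, 2-(hydroxycarbamoyl)ethyl stands in place of hydroxycarbamoyl on a saturated chain carbon, four bonds along the chain from an oxygen on an aromatic ring.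

Going by the values given here, only one measured step bears on this change. There, (hydroxycarbamoyl)methyl replaced hydroxycarbamoyl on the same chain, giving a 2.5-fold lower number from compound 1 to compound 2 (0.39 log units; beyond the scatter), a modest step but beyond the scatter. The change now in question adds more to the chain than that one did, yet a single step cannot show whether the drop will continue. The expected step, toward a lower number, is a 2.5-fold lower number from compound 2 to compound 3 (0.40 log units; beyond the scatter). For compound 3 the estimated value is 1000 nM, with a range from 330 nM to 3000 nM.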

Compound 3, half-maximal inhibitory concentration: 1210 nM
For compound 3 the middle estimate is 1.2-fold (0.08 log units) below the measured one, within the range that was stated.
By their numbers in this assay, from the lowest: compound 3; then compound 2; then compound 1.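

In this assay, a second lengthening at this position again lowers the number, with a 2.1-fold lower number from compound 2 to compound 3 (0.32 log units; beyond the scatter), so the fall seen at the first step does not stop at compound 2. Taken end to end, 3-(hydroxycarbamoyl)propyl in place of hydroxycarbamoyl gives a 5.1-fold lower number from compound 1 to compound 3 (0.71 log units; beyond the scatter), and across these three compounds the number falls as the chain grows, with none of them going against that order. No measurement at hand explains why a longer chain goes with a lower number.

The compounds shown leave open how far this trend runs: a longer chain than the one in compound 3 could lower the number further, level off or reverse the direction, and three compounds cannot locate any best length. They also leave open whether the chain's end group matters as much as its length, which a carboxylic acid in place of the hydroxycarbamoyl end, at the same chain length as compound 3, would begin to test.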